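The source may hold more compounds than are shown below. What is called first, only, known or untested is meant among the compounds shown, and "the series" means these compounds.

Among the compounds with values here, compound 1 `O=C(C1CC12CCC2)N1CCc2nc(C#Cc3ccccc3)sc2C1` is the only member of this small set with a numeric reading: in an assay on HEK293 cells for positive allosteric modulation of metabotropic glutamate receptor 5 (Homo sapiens), read by FLIPR, with a stated time of 1 h (on this read-out lower numbers stand for an effect already at smaller amounts and higher numbers for an effect only at larger amounts of compound), compound 1 gives 3.9 nM. Compound 2 `CC(C)S(=O)(=O)N1Cc2nc(C#Cc3ccccc3)sc2C1` offers no number: in this assay compound 2 reaches only a limit of the assay, > 10000 nM. That reading is the limit of > 10000 nM in this assay, at which 1 of the 2 values shown sits. Within the data shown here, with no two numbers to set against each other, no measured step exists here, and compound 1 stands alone as the single point from which anything can be read.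

Compound 3 `O=C(N1CCCC1)N1CCc2nc(C#Cc3ccccc3)sc2C1` is the untested neighbour of compound 1. It differs in one place: a group of 5 heavy atoms (4 carbon, 1 nitrogen; one five-membered non-aromatic ring with 1 hetero atom) in place of a group of 6 heavy atoms (6 carbon; one three-membered non-aromatic ring of carbon only, one four-membered non-aromatic ring of carbon only), on a carbonyl carbon. Both groups sit on a carbonyl carbon whose other neighbour is an amide-type nitrogen in a ring. Among the measured compounds shown here, with no measured step of this kind to lean on, a modest loss is expected, a step of a 3.8-fold higher number from compound 1 to compound 3 (0.59 log units; beyond the scatter) that would only just pass the usual scatter. Compound 3 is therefore estimated at 15 nM, with a range from 3 nM to 80 nM.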

Compound 3, half-maximal effective concentration: 9.8 nM
For compound 3 the middle estimate is 1.5-fold (0.18 log units) above the measured one, and the stated range covers the measured number.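

At this place, on a carbonyl carbon whose other neighbour is an amide-type nitrogen in a ring, the change to pyrrolidin-1-yl in this assay gives a 2.5-fold higher number from compound 1 to compound 3 (0.40 log units; beyond the scatter) as a modest step. The group of 6 carbon atoms with its three-membered and four-membered rings is therefore not required for a low number, as compound 3 with its ring containing nitrogen still reads 9.8 nM on this read-out. Nothing measured here gives a reason for this step.

On these data alone, whether piperidin-1-yl, morpholin-4-yl or an open chain such as tert-butyl on the same carbonyl carbon would keep the reading stays open. Within the data shown here, the single step also cannot separate the part played by the ring nitrogen from that played by the ring sizes.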